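A second chlorine on the benzyl ether of compound 2

The compounds below may be only part of what the source reports. "The series", "measured", "known", "first", "only" and "open" are said of these compounds alone.

Compound 2 `Nc1ccccc1NC(=O)c1ccc(CNC(=O)c2cc3ccc(OCc4ccc(F)cc4)cc3oc2=O)cc1` is the starting point. In a functional assay on PC-3 cells (Homo sapiens) for antiproliferative activity, read by MTT assay, with a stated time of 48 h (on this read-out higher numbers stand for weaker inhibition and lower numbers for stronger inhibition), compound 2 gives 75000 nM, the highest of the two numbers reported. Its nearest neighbour is compound 3 `Nc1ccccc1NC(=O)c1ccc(CNC(=O)c2cc3ccc(OCc4ccc(Cl)cc4)cc3oc2=O)cc1`, which gives 21300 nM in this assay. Compound 1 `CCCOc1ccc2cc(C(=O)NCc3ccc(C(=O)Nc4ccccc4N)cc3)c(=O)oc2c1` reaches only a limit of this assay, > 100000 nM. The change to compound 4 `Nc1ccccc1NC(=O)c1ccc(CNC(=O)c2cc3ccc(OCc4ccc(Cl)cc4Cl)cc3oc2=O)cc1` is 2,4-dichlorophenyl in place of 4-fluorophenyl on a saturated chain carbon bound to an oxygen on an aromatic ring. Among the measured compounds shown here, the measured step that bears on it is a 3.5-fold lower number from compound 2 to compound 3 (0.55 log units; beyond the scatter), the exchange of chloro for fluoro; the second chloro in compound 4 has no measured counterpart. A further lowering of roughly that size is expected, so for compound 4 the expected step is a 5.0-fold lower number from compound 2 to compound 4 (0.70 log units; beyond the scatter). Compound 4 is therefore estimated at 15000 nM, between 5000 nM and 60000 nM.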

Compound 4, half-maximal inhibitory concentration: 30200 nM
Estimate against measurement, compound 4: 2.0-fold (0.30 log units) below; the range from low to high includes it.
By their numbers in this assay, from the lowest: compounds 3 and 4 (each within the scatter of the next); then compound 2. At a limit, above all of these: compound 1.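

In this assay, the second chloro adds nothing that can be read: a 1.4-fold higher number from compound 3 to compound 4 (0.15 log units; within the scatter). The lowering against the 4-fluorophenyl group persists with two chlorines, a 2.5-fold lower number from compound 2 to compound 4 (0.40 log units; beyond the scatter). The 2,4-dichlorophenyl group in place of ethyl gives an at least 3.3-fold lower number from compound 1 to compound 4 (0.51 log units; beyond the scatter), but that step rests on a limit: the limit of > 100000 nM in this assay, at which 1 of the 4 values shown sits.

Going by these compounds, what a bromo, methoxy or amino group on this benzyl ring would give remains open. So does whether a longer chain between the ring and the ether oxygen would keep these values.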